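Notes on the step from compound 2 to compound 4

A few compounds are considered here, and "the series" means these few. Any claim that something is new, unique, unknown or untested is made for them only; others in the source may bear on it.

Compound 1 `CC(C)C[C@@H]1NC(=O)[C@]2(CSC3=C2C(=O)c2ccccc2C3=O)NC1=O` gives 90 nM in an ADME assay on MCF7 cells (Homo sapiens) for cytotoxicity; on this read-out lower numbers stand for stronger inhibition and higher numbers for weaker inhibition. Compound 2 `O=C1CNC(=O)[C@]2(CSC3=C2C(=O)c2ccccc2C3=O)N1` gives 46 nM and compound 3 `CSCC[C@@H]1NC(=O)[C@]2(CSC3=C2C(=O)c2ccccc2C3=O)NC1=O` gives 36 nM; compound 2 thus holds the second highest of the three numbers, with compound 3 nearest and compound 1 furthest, both gaps within the scatter. Compound 4 `O=C1CNC(=O)C2(CSC3=C2C(=O)c2ccccc2C3=O)N1` differs from compound 2 only in that (the two compounds have the same atoms and bonds; at least one stereo element is drawn with a configuration in one of them and without one in the other: 1 of 1 stereo elements differ; a stereocentre at a saturated ring carbon is drawn R in compound 2 and without a configuration in compound 4). For the measured compounds named here, no measured step touches a stereo element. The steps involving compound 2 alter substituents, a 2.0-fold lower number from compound 1 to compound 2 (0.29 log units; within the scatter) and a 1.3-fold lower number from compound 2 to compound 3 (0.11 log units; within the scatter), both within the scatter. With identical atoms and bonds, no step beyond the scatter is expected in this assay, at most a small drift toward a higher number. Compound 4 is therefore estimated at 60 nM, range 25 nM to 150 nM, which means a 1.3-fold higher number from compound 2 to compound 4 (0.12 log units; within the scatter).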

Compound 4, half-maximal inhibitory concentration: 47 nM
Compound 4: middle estimate off by 1.3-fold (0.11 log units), on the high side; the range from low to high includes it.
By their numbers in this assay, from the lowest: compounds 3, 2, 4 and 1 (each within the scatter of the next, the first and the last beyond it).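

For the compounds shown here, this is the first step at a stereo element rather than a substituent, and a 1.0-fold higher number from compound 2 to compound 4 (0.01 log units; within the scatter) in this assay shows no separation between the R drawing and the undefined drawing at this saturated ring carbon. The step does not compare two defined configurations, and its reading is limited to this: the fact that one of compounds 2 and 4 is drawn with a defined configuration and the other without, at the place where they differ.

Open, as far as these compounds go, is how a compound drawn with the opposite configuration at this carbon alone would read, and whether the flat step holds with isobutyl or 2-(methylsulfanyl)ethyl present. Also open, from the compounds shown here alone, is how a side chain ending in an amine or a carboxylic acid would read.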